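Methyl on the chain carbon in two cores

The compounds below may be only part of what the source reports. "The series", "measured", "known", "first", "only" and "open" are said of these compounds alone.

Values in a functional assay on the whole organism for antagonist activity, with Mus musculus as the target; on this read-out higher numbers stand for an effect only at larger amounts of compound and lower numbers for an effect already at smaller amounts:
Compound 1 `CC(=O)N(C)C(C)C#CCn1cncc1C` gives 3.7 mg/kg.
Compound 2 `CC(=O)N(C)CC#CCn1cncc1C` gives > 100 mg/kg, which is a limit of the assay.
Compound 3 `COC(=O)N(C)CC#CCN1CCCC1` gives > 10 mg/kg, which is a limit of the assay.

Compound 4 `COC(=O)N(C)C(C)C#CCN1CCCC1` has not been measured in this assay. The difference between the core of compound 2 and the core of compound 3 is not broken down here. One change, (methyl in place of hydrogen on a saturated chain carbon bound to an amide-type nitrogen and a triple-bonded carbon), gave a large step, an at least 27-fold lower number from compound 2 to compound 1 (1.43 log units; beyond the scatter), starting from the limit of > 100 mg/kg in this assay, at which 1 of the 3 values shown sits. The same change, (methyl in place of hydrogen on a saturated chain carbon bound to an amide-type nitrogen and a triple-bonded carbon), is made from compound 3 to compound 4, starting from the limit of > 10 mg/kg in this assay, at which 1 of the 3 values shown sits. Among the compounds with values here, a step of about the earlier size is expected, estimated as an at least 2.0-fold lower number from compound 3 to compound 4 (0.30 log units; that floor lies within the scatter) in this assay, resting on the single measured instance alone. For compound 4 the expected value in this assay is 5 mg/kg, with a likely range from 1.5 mg/kg to 30 mg/kg.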

Compound 4, dose for half-maximal effect: > 100 mg/kg
Compound 4: only a limit was reported; the forecaster's own chance of this, stated with the estimate: 30%; at least 20-fold (1.30 log units) between middle value and limit.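

In this assay compound 3 and compound 4 both give only limits, and no step can be read between them. On these data alone, what the methyl in place of hydrogen does in the core of compound 3 stays open.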